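From a 2-methoxyphenyl to an anilino group

The source may report more compounds than this note shows. Statements on the series, on what has been measured and on what is new or still open speak of the compounds shown alone.

Of the compounds shown here, three on a shared core have been measured so far. In a functional assay on K562 cells (Homo sapiens) for antiproliferative activity, read by MTT assay, with a stated time of 72 h (on this read-out lower numbers stand for stronger inhibition and higher numbers for weaker inhibition), compound 1 (`COc1cc(C(=O)c2sc3ccccc3c2-c2ccc(Cl)cc2)cc(OC)c1OC`) gives 4200 nM as its result. Compound 2 (`COc1ccc(-c2c(C(=O)c3cc(OC)c(OC)c(OC)c3)sc3ccccc23)cc1`) gives 1700 nM in the same test of this assay and compound 3 (`COc1ccccc1-c1c(C(=O)c2cc(OC)c(OC)c(OC)c2)sc2ccccc12`) gives 3400 nM there. Methoxy in place of chloro produces a 2.5-fold lower number from compound 1 to compound 2 (0.39 log units; beyond the scatter) and this modest step lies beyond the scatter. The other two steps are a 1.2-fold lower number from compound 1 to compound 3 (0.09 log units; within the scatter) and a 2.0-fold higher number from compound 2 to compound 3 (0.30 log units; within the scatter) and both lie within it. Compound 3 therefore stands within the scatter of both other compounds, even though those two are separated from each other.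

Compound 4 (`COc1cc(C(=O)c2sc3ccccc3c2Nc2ccccc2)cc(OC)c1OC`) carries anilino in place of 2-methoxyphenyl on an aromatic carbon of the five-membered aromatic ring with 1 sulfur: anilino in place of 2-methoxyphenyl on an aromatic carbon is the whole difference. Among the measured compounds shown here, no measured compound carries anilino, so no measured step tests this swap directly. The nearest guides are the changes among the substituted phenyl groups, and the largest of them is only a 2.5-fold lower number from compound 1 to compound 2 (0.39 log units; beyond the scatter) in size. On that basis, no step beyond the scatter is expected in this assay and the estimated change is a 1.7-fold lower number from compound 3 to compound 4 (0.23 log units; within the scatter) with little confidence in its direction. For compound 4 the estimated value is 2000 nM within an expected range from 400 nM to 8000 nM and that width reflects the untested anilino.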

Compound 4, half-maximal inhibitory concentration: 2300 nM
Compound 4: the middle estimate sits 1.2-fold (0.06 log units) below what was measured; measured number inside the range.
By their numbers in this assay, from the lowest: compounds 2, 4, 3 and 1 (each within the scatter of the next, the first and the last beyond it).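

In this assay, this aromatic carbon of the five-membered ring with 1 sulfur takes anilino in place of a substituted phenyl group with no step beyond the scatter (a 1.5-fold lower number from compound 3 to compound 4 (0.17 log units; within the scatter)). The same holds against the other two earlier compounds (a 1.4-fold higher number from compound 2 to compound 4 (0.13 log units; within the scatter); a 1.8-fold lower number from compound 1 to compound 4 (0.26 log units; within the scatter)). So this position tolerates more than the phenyl groups alone had shown, and the swap from 2-methoxyphenyl, with 0 hydrogen-bond donors, to anilino, with 1 hydrogen-bond donor, leaves no readable mark on this read-out, while nothing measured here offers an explanation for that.

Still open, from the compounds shown here alone, is how far this tolerance extends to groups without an aromatic ring, such as a plain amino group, a morpholine ring or a short alkyl chain, and whether a benzylamino group, with its longer chain to the ring, would behave like anilino. Also open, going by these compounds, is whether a methoxy or chloro group on the anilino ring would separate compounds in the way that methoxy and chloro did on the phenyl ring (a 2.5-fold lower number from compound 1 to compound 2 (0.39 log units; beyond the scatter)).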